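This account rests on a few compounds, and the source may have more. Where it says the series, first, only, none or still open, it means among the compounds named here.

Measured compounds in an ADME assay on HeLa cells (Homo sapiens) for cytotoxicity, read by ATP content, with a stated time of 3 days; on this read-out lower numbers stand for higher toxicity in this test and higher numbers for lower toxicity in this test:

compound 1 `O=c1n(Cc2cc3cc(Cl)ccc3n2CCCCF)c2cnccc2n1C1CC1` gives > 50000 nM, a limit of the assay.
compound 2 `N#CCCCn1c(Cn2c(=O)n(C3CC3)c3ccncc32)nc2nc(Cl)ccc21` gives > 50000 nM, a limit of the assay.
compound 3 `N#CCCCn1c(Cn2c(=O)n(C3CC3)c3ccncc32)cc2cc(Cl)ccc21` gives > 50000 nM, a limit of the assay.

Within the data shown here, every value so far sits at the limit of > 50000 nM in this assay, at which 3 of the 3 values shown sit, so no compound is separated from another here. The change from compound 3 to compound 1 is fluoromethyl in place of cyano on a saturated chain carbon, three bonds along the chain from an aromatic nitrogen and produces a step that the two limits leave unreadable from compound 3 to compound 1; with both ends at the limit, its size cannot be read.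

Compound 4 `O=c1n(Cc2nc3nc(Cl)ccc3n2CCCCF)c2cnccc2n1C1CC1` is not yet measured. It differs from compound 2 by fluoromethyl in place of cyano on a saturated chain carbon, three bonds along the chain from an aromatic nitrogen, the same change as before, now made on the core of compound 2; the difference between the cores of compound 2 and compound 3 is not broken down here.

For compound 4 the expected step is a step that the limit leaves unreadable from compound 2 to compound 4, set beside a step that the two limits leave unreadable from compound 3 to compound 1, and it rests on (the limit of > 50000 nM in this assay, at which 3 of the 3 values shown sit), where all three measured values sit. Compound 4 is therefore expected at 80000 nM, estimated between 40000 nM and 200000 nM, most probably reported as a limit once more.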

Compound 4, half-maximal cytotoxic concentration: > 50000 nM
Compound 4 gave a limit, no number; the forecaster's own chance of this, stated with the estimate: 85%; the middle value does not contradict the limit.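

In this assay compound 4 gives > 50000 nM, a limit and not a number. Compound 2 and compound 4 therefore yield no readable step, and no new step can be read: the limit of > 50000 nM in this assay, at which 4 of the 4 values shown sit.

The compounds shown leave open whether fluoromethyl in place of cyano changes the half-maximal cytotoxic concentration on either core.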